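The source may hold more compounds than are shown below. What is called first, only, known or untested is meant among the compounds shown, and "the series" means these compounds.

Compound 1 `COc1ccc(-c2nnc(N3CCN(C(=O)CN4CCN(c5cccc(Cl)c5)CC4)CC3)nc2-c2ccc(OC)cc2)cc1` and compound 2 `COc1ccc(-c2nnc(N3CCN(C(=O)CN4CCN(c5ccc(Cl)cc5)CC4)CC3)nc2-c2ccc(OC)cc2)cc1` share one core and differ only in the aryl on the piperazine nitrogen. In a functional assay on MCF7 cells (Homo sapiens) for cytotoxicity, read by MTT assay, with a stated time of 24 h (a higher number here means a weaker inhibitor, a lower number a stronger inhibitor), compound 1 returns only a limit, > 814000 nM. In this assay, going by the values given here, compound 2 gives 607000 nM, the only actual number in the set. The step of an at least 1.3-fold lower number from compound 1 to compound 2 (0.12 log units; that floor lies within the scatter) therefore rests on a limit, (the limit of > 814000 nM in this assay, at which 1 of the 2 values shown sits), and its floor sits within the scatter.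

Compound 3 `COc1ccc(-c2nnc(N3CCN(C(=O)CN4CCN(c5ccc([N+](=O)[O-])cc5)CC4)CC3)nc2-c2ccc(OC)cc2)cc1` carries nitro in place of chloro on an aromatic carbon. Among the compounds with values here, no measured step involves a nitro group, so the change from compound 2 is uncharted; the sole step, from 3-chlorophenyl to 4-chlorophenyl, says nothing about it. For compound 3 the estimate in this assay is 600000 nM, between 250000 nM and 1500000 nM, a step of a 1.0-fold lower number from compound 2 to compound 3 (0.01 log units; within the scatter), expected to stay within the scatter.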

Compound 3, half-maximal inhibitory concentration: > 801000 nM
Compound 3: a limit, no number (the forecaster's own chance of this, stated with the estimate: 40%); middle value at least 1.3-fold (0.12 log units) away from the limit.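

In this assay compound 3 returns only a limit, > 801000 nM, so at this position 4-nitrophenyl, like 3-chlorophenyl in compound 1, yields no actual number. Nitro in place of chloro gives an at least 1.3-fold higher number from compound 2 to compound 3 (0.12 log units; that floor lies within the scatter), and this step rests on a limit: the limit of > 801000 nM in this assay, at which 1 of the 3 values shown sits. The step linking the two limits cannot be read.

As far as these compounds go, whether an amine or a carboxylic acid para to a large group would give a number in this assay stays open. From the compounds shown here alone, the true size of the change from chloro to nitro also stays open.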